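A few compounds are considered here, and "the series" means these few. Any claim that something is new, unique, unknown or untested is made for them only; others in the source may bear on it.

Measured in a functional assay on DU-145 cells (Homo sapiens) for cytotoxicity, read by MTT assay, with a stated time of 68 h (a lower number here means a stronger inhibitor, a higher number a weaker inhibitor), so far:
- compound 1 `O=C(/C=C/c1cccc(OCc2ccccc2)c1)c1ccc(O)cc1` gives 6300 nM
- compound 2 `Cc1ccc(C(=O)/C=C/c2cccc(OCc3ccccc3)c2)cc1` gives 25600 nM

Of these two, compound 2 has the higher number at 25600 nM and compound 1 is its nearest neighbour. Next comes compound 3 `O=C(/C=C/c1cccc(OCc2ccccc2)c1)c1cccc(Br)c1`, which differs from compound 2 by 3-bromophenyl in place of 4-methylphenyl on a carbonyl carbon with 3-bromophenyl in place of 4-methylphenyl on a carbonyl carbon. Within the data shown here, only one measured step bears on this change, and only indirectly: a 4.1-fold higher number from compound 1 to compound 2 (0.61 log units; beyond the scatter) is a modest step, with methyl in place of hydroxy on an aromatic carbon of that same ring. Among the measured compounds shown here, no measured compound in this assay carries bromine, so the direction is weakly grounded. For the measured compounds named here, a step no larger than that one is expected, leaning slightly towards a lower number, as compound 2 is the higher of only two values. The estimated step is a 1.7-fold lower number from compound 2 to compound 3 (0.23 log units; within the scatter) and its direction could still reverse. Compound 3 is estimated at 15000 nM with an expected range from 6000 nM to 40000 nM in this series.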

Compound 3, half-maximal inhibitory concentration: 9100 nM
The estimate for compound 3 lay 1.6-fold (0.22 log units) above the measured number, and the stated range covers the measured number.
By their numbers in this assay, from the lowest: compounds 1 and 3 (each within the scatter of the next); then compound 2.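

In this assay, the group on the carbonyl carbon moves the number by more than the scatter a second time: 3-bromophenyl in place of 4-methylphenyl gives a 2.8-fold lower number from compound 2 to compound 3 (0.45 log units; beyond the scatter). Replacing 4-hydroxyphenyl with 3-bromophenyl gives a 1.4-fold higher number from compound 1 to compound 3 (0.16 log units; within the scatter), so among these compounds a hydroxy group on this ring is not needed to reach the level of compound 1, and the two cannot be ordered. No measurement shown here accounts for either step.

The change from compound 2 to compound 3 swaps the substituent and also its place on the ring, so these compounds cannot separate the contribution of the bromine from that of its location. On these data alone, how an amine or a carboxylic acid on this ring would compare remains open, as does whether the same ranking of these three groups would hold with the benzyloxy group of the shared core replaced.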